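Branching the chain on the aromatic nitrogen

This account rests on a few compounds, and the source may have more. Where it says the series, first, only, none or still open, it means among the compounds named here.

Measured in a functional assay on the whole organism (strain Holtzman) with Rattus norvegicus as the target; a higher number here means that more compound is needed for the effect, a lower number that less compound is needed:
Compound 1, `CCn1nc(C)c2c1NC(=O)CN=C2c1ccccc1Cl`: 5 mg/kg
Compound 2, `C=CCN1C(=O)CN=C(c2ccccc2Cl)c2c(C)nn(CC)c21`: > 40 mg/kg, a limit of the assay, not a number

In this assay, within the data shown here, compound 1 gives 5 mg/kg, the only firm number here. Compound 3, `Cc1nn(C(C)C)c2c1C(c1ccccc1Cl)=NCC(=O)N2`, differs from compound 1 by methyl in place of hydrogen on a saturated chain carbon bound to an aromatic nitrogen and a saturated chain carbon. Among the measured compounds shown here, the single measured step, an at least 8.0-fold higher number from compound 1 to compound 2 (0.90 log units; beyond the scatter), concerns the amide-type nitrogen in a ring rather than the chain on the aromatic nitrogen, so it offers no direct guide, and the evidence the limit of > 40 mg/kg in this assay, at which 1 of the 2 values shown sits, describes only that step. For compound 3 a step no larger than the usual scatter is expected, a 1.6-fold higher number from compound 1 to compound 3 (0.20 log units; within the scatter). Compound 3 is therefore estimated at 8 mg/kg, with a range from 3 mg/kg to 25 mg/kg.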

Compound 3, minimum effective dose: 20 mg/kg
Estimate against measurement, compound 3: 2.5-fold (0.40 log units) below; measured number inside the range.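

The chain on the aromatic nitrogen is a position where a small change counts: in this assay, ethyl to isopropyl gives a 4.0-fold higher number from compound 1 to compound 3 (0.60 log units; beyond the scatter) and so needs more compound for the effect. One added methyl on the saturated chain carbon is enough for a step beyond the scatter, and this step involves a different position from the amide-type nitrogen. Nothing shown gives a measured reason for this step.

As far as these compounds go, it remains open whether the extra carbon or the branching itself matters, which a straight propyl chain could help to separate. From the compounds shown here alone, how a cyclopropyl ring or a hydroxyethyl chain on the same nitrogen would behave is also open.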